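Propylamide to 4-chlorobenzylamide on a weakly cytotoxic core

The source may report more compounds than this note shows. Statements on the series, on what has been measured and on what is new or still open speak of the compounds shown alone.

Compound 1 `C=CC1=C(C(=O)NCCC)C(c2ccc(F)cc2)OC1` is tested in a functional assay on HeLa cells (Homo sapiens) for cytotoxicity, read by MTT assay, with a stated time of 24 h; a lower number here means a stronger inhibitor, a higher number a weaker inhibitor. In this assay compound 1 reaches only the limit > 100000 nM, which is a limit rather than a number. Compound 2 `C=CC1=C(C(=O)O)C(c2ccc(F)cc2)OC1`, the acid, gives 67400 nM in this assay, so the step of an at least 1.4-fold lower number from compound 1 to compound 2 (0.17 log units; that floor lies within the scatter) is small. Compound 3 `C=CC1=C(C(=O)NCCC)C(c2ccc(Cl)c(Cl)c2)OC1` also sits at the limit > 100000 nM in this assay. Compound 4 `C=CC1=C(C(=O)NCc2ccc(Cl)cc2)C(c2ccc(F)cc2)OC1` differs from compound 1 by 4-chlorophenyl in place of ethyl on a saturated chain carbon bound to an amide-type nitrogen. For the measured compounds named here, no measured step bears on this change; the only measured step, an at least 1.4-fold lower number from compound 1 to compound 2 (0.17 log units; that floor lies within the scatter), concerns a different position and is within the scatter, and two of the three values sit at the limit of > 100000 nM in this assay, at which 2 of the 3 values shown sit. A step that the limit leaves unreadable from compound 1 to compound 4 is therefore expected, with little change beyond the scatter. Compound 4 is estimated at 120000 nM, between 40000 nM and 300000 nM.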

Compound 4, half-maximal inhibitory concentration: > 100000 nM
Compound 4: only a limit was reported; the forecaster's own chance of this, stated with the estimate: 70%; the middle value does not contradict the limit.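

In this assay compound 4 gives > 100000 nM, which is a limit and not a number. For the compounds shown here, compound 1 also stands at a limit, so no step between compound 1 and compound 4 can be read. The compounds shown leave open whether propyl to 4-chlorobenzyl changes cytotoxicity at all: the limit of > 100000 nM in this assay, at which 3 of the 4 values shown sit.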